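One added carbon on the side chain of compound 1

The source may report more compounds than this note shows. Statements on the series, on what has been measured and on what is new or still open speak of the compounds shown alone.

compound 1 `COc1cc(/C=C/C(=O)/C=C(/C=C/c2ccc(O)c(OC)c2)NCCO)ccc1O` gives 11800 nM
compound 2 `COc1cc(/C=C/C2=CC(=O)CC(c3ccc(O)c(OC)c3)N2CCCO)ccc1O` gives 62900 nM
compound 3 `COCCCN1C(/C=C/c2ccc(O)cc2)=CC(=O)CC1c1ccc(O)cc1` gives 38800 nM

All three were measured in a physicochemical assay for solubility, using the shake flask method, in phosphate buffer, with a stated time of 24 h, at pH 6.8 (on this read-out lower numbers stand for lower solubility and higher numbers for higher solubility), and compound 1 holds the lowest number, with compound 2 and compound 3 both higher beyond the scatter. Compound 4 `COc1cc(/C=C/C(=O)/C=C(/C=C/c2ccc(O)c(OC)c2)NCCCO)ccc1O` has not yet been measured. It carries hydroxymethyl in place of hydroxy on a saturated chain carbon, two bonds along the chain from an amine nitrogen. Among the measured compounds shown here, no measured pair shows this change alone, so the expectation starts from compound 1 at 11800 nM and foresees no step beyond the scatter. The estimated step is small (a 1.2-fold lower number from compound 1 to compound 4 (0.07 log units; within the scatter)). Compound 4 is estimated at 10000 nM with a range of (4500 nM to 24000 nM).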

Compound 4, solubility: 56300 nM
The estimate for compound 4 lay 5.6-fold (0.75 log units) below the measured number; the whole stated range lies below it.
By their numbers in this assay, from the lowest: compound 1; then compounds 3, 4 and 2 (each within the scatter of the next).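

In this assay, going from (2-hydroxyethyl)amino to (3-hydroxypropyl)amino gave a 4.8-fold higher number from compound 1 to compound 4 (0.68 log units; beyond the scatter) and so showed that this position, on a saturated chain carbon, responds to one added carbon. The change leaves the hydrogen-bond donor and acceptor counts as they were, so the step comes with no difference in those counts. Nothing measured here accounts for the step. Going by these compounds, whether a longer chain would extend the step remains open, as does the outcome of an amine or a carboxylic acid in place of the hydroxy.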